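A Thioester Gives Way to a Branched Ester

A few compounds are considered here, and "the series" means these few. Any claim that something is new, unique, unknown or untested is made for them only; others in the source may bear on it.

Compound 1 `CC1=C(C(=O)OC(C)(C)C)C(c2ccsc2)NC(=O)N1` gives 47% in an assay on membranes from HEK293 cells for displacement of a labelled ligand from adenosine receptor A2b (Homo sapiens), read by scintillation counting, with a stated time of 30 min, tested at 1 uM; a lower number here means less inhibition, a higher number more inhibition at the concentration tested (going by the name of the read-out).
Compound 2 `CCSC(=O)C1=C(C)NC(=O)NC1c1ccsc1` gives 17% in this assay.

Among the compounds with values here, compound 2 stands lowest of the two measured compounds; its nearest neighbour is compound 1, and the one measured step between them, a number 30 percentage points lower from compound 1 to compound 2 (beyond the scatter), lies beyond the scatter. Compound 3 `CCC(CC)OC(=O)C1=C(C)NC(=O)NC1c1ccsc1` is not yet measured. It differs from compound 2 in one place: (pentan-3-yl)oxy in place of ethylsulfanyl on a carbonyl carbon. Within the data shown here, the only step that bears on this change is the one from compound 1 to compound 2, where an oxygen-linked group was exchanged for a sulfur-linked one and the number fell by a modest amount. The new change returns an oxygen-linked group to the same carbonyl carbon, so a rise of roughly that size is expected, a number 25 percentage points higher from compound 2 to compound 3 (beyond the scatter). Compound 3 is therefore estimated at 42%, with a range from 22% to 62%.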

Compound 3, a percentage reported as inhibition, at one concentration (the size of the read-out at that concentration, not a potency): 26%
Compound 3: the middle estimate sits 16 percentage points above what was measured; the range from low to high includes it.
By their numbers in this assay, from the lowest: compounds 2 and 3 (each within the scatter of the next); then compound 1.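

Putting an oxygen link back on the carbonyl carbon does not by itself restore the higher number: in this assay, (pentan-3-yl)oxy in place of ethylsulfanyl gives a number 9 percentage points higher from compound 2 to compound 3 (within the scatter), a step too small to separate the two compounds. With the oxygen link kept, pentan-3-yl in place of tert-butyl gives a number 21 percentage points lower from compound 1 to compound 3 (beyond the scatter), so the group carried on that oxygen also shifts the number, and an oxygen link alone does not settle the result at this position. No supporting measurement is available to explain either step.

The exchange of ethylsulfanyl for (pentan-3-yl)oxy alters both the linking atom and the chain, so the effect of each alone stays unresolved; an ethoxy ester would compare the two linking atoms with the same ethyl chain. From the compounds shown here alone, how an amide made from a simple amine, or a free carboxylic acid, would behave at this carbonyl carbon also remains open.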